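The source may report more compounds than this note shows. Statements on the series, on what has been measured and on what is new or still open speak of the compounds shown alone.

Compound 1 `CC[C@@H]1/C=C(\C)C[C@H](C)C[C@H](OC)[C@H]2O[C@@](O)(C(=O)C(=O)N3CCCC[C@H]3C(=O)O[C@H](/C(C)=C/[C@@H]3CC[C@@H](Oc4ccccc4)[C@H](OC)C3)[C@H](C)[C@@H](O)CC1=O)[C@H](C)C[C@@H]2OC` and compound 2 `CC[C@@H]1/C=C(\C)C[C@H](C)C[C@H](OC)[C@H]2O[C@@](O)(C(=O)C(=O)N3CCCC[C@H]3C(=O)O[C@H](/C(C)=C/[C@@H]3CC[C@@H](Oc4ccccc4)[C@H](O)C3)[C@H](C)[C@@H](O)CC1=O)[C@H](C)C[C@@H]2OC` share a macrocyclic core and differ only at one oxygen on a saturated carbon. In a functional assay on cells for inhibition, with Murine T-cell line (Mus musculus) as the target (a lower number here means a stronger inhibitor, a higher number a weaker inhibitor), compound 1 gives 5.4 nM, and in this assay compound 2 gives 5.2 nM. The step of a 1.0-fold lower number from compound 1 to compound 2 (0.02 log units; within the scatter) shows that this part of the molecule tolerates the loss of a methyl without a change beyond the scatter. Compound 2 has the lowest number of the two, though the gap to compound 1 is within the scatter, so no order between them can be claimed.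

Compound 3 `CC[C@@H]1/C=C(\C)C[C@H](C)C[C@H](OC)[C@H]2O[C@@](O)(C(=O)C(=O)N3CCCC[C@H]3C(=O)O[C@H](/C(C)=C/[C@@H]3CC[C@@H](Oc4ccc(O)cc4)[C@H](O)C3)[C@H](C)[C@@H](O)CC1=O)[C@H](C)C[C@@H]2OC` differs from compound 2 by hydroxy in place of hydrogen on an aromatic carbon. Within the data shown here, no measured step touches the aromatic ring, so the only guidance is the nearby change in compound 2, which was within the scatter. Compound 3 is therefore expected to show a 1.3-fold higher number from compound 2 to compound 3 (0.13 log units; within the scatter), with little change in this assay. The estimated value for compound 3 is 7 nM, within a range from 2.5 nM to 20 nM.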

Compound 3, half-maximal inhibitory concentration: 1.6 nM
Beside the measured number, compound 3's estimate is 4.4-fold (0.64 log units) above it; measured number outside the range, below it.
By their numbers in this assay, from the lowest: compound 3; then compounds 2 and 1 (each within the scatter of the next).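

The phenoxy group proves responsive to substitution: in this assay, hydroxy in place of hydrogen on the aromatic carbon para to a large group gives a 3.3-fold lower number from compound 2 to compound 3 (0.51 log units; beyond the scatter), a modest step. The only earlier step, at the oxygen on a saturated carbon, stayed within the scatter, so this is the first change shown that moves the number beyond it. Nothing available bears on why the number falls at this position.

The compounds shown leave open whether this step is specific to hydroxy, or whether a methoxy group, a fluorine atom or an amine at the same place would give a similar one. They also leave open whether the step would hold with the methoxy group of compound 1 kept on the saturated carbon, since 4-hydroxyphenoxy appears here only with the hydroxy found there in compound 2.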